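Compound 3 to compound 4: bringing back an amide

This account rests on a few compounds, and the source may have more. Where it says the series, first, only, none or still open, it means among the compounds named here.

Three related compounds have been measured in a functional assay (strain AB) with Danio rerio as the target, read by microscopy, with a stated time of 1 h; on this read-out lower numbers stand for an effect already at smaller amounts and higher numbers for an effect only at larger amounts of compound. Compound 1 `CCN1CCc2c(sc(NC(=O)Nc3ccc(Cl)cc3)c2C(N)=O)C1` gives 3120 nM. Compound 2 `CCN1CCc2c(sc(NC(=O)Nc3ccc(Cl)cc3)c2C#N)C1` gives only a limit of the assay, > 25000 nM, and not a number. Compound 3 `CCN1CCc2c(sc(NC(=O)Nc3ccc(Cl)cc3)c2C(=O)c2nnco2)C1` also gives only a limit, > 25000 nM, and so stands with compound 2 at the limit of > 25000 nM in this assay, at which 2 of the 3 values shown sit.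

The next structure, compound 4 `CCN1CCc2c(sc(NC(=O)Nc3ccc(Cl)cc3)c2C(=O)NCCO)C1`, has not yet been measured. The change is (2-hydroxyethyl)amino in place of 1,3,4-oxadiazol-2-yl on a carbonyl carbon.

The closest measured step concerns that same carbonyl carbon: an at least 8.0-fold higher number from compound 1 to compound 3 (0.90 log units; beyond the scatter). This step lies beyond the scatter, as does the one with cyano in place of carbamoyl, an at least 8.0-fold higher number from compound 1 to compound 2 (0.90 log units; beyond the scatter). Of the three measured compounds, only compound 1 has a nitrogen on that carbonyl carbon, and only compound 1 gives a number. For the measured compounds named here, compound 4 brings such a nitrogen back, but it carries a hydroxyethyl chain that no measured compound has, so a full return to the value of compound 1 is not assumed. A lower number than the limit of compound 3 is therefore expected, in the form an at least 2.7-fold lower number from compound 3 to compound 4 (0.44 log units; beyond the scatter). For compound 4 the estimate is 9000 nM, with an expected range from 2500 nM to 25000 nM.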

Compound 4, half-maximal effective concentration: 9400 nM
The estimate for compound 4 lay 1.0-fold (0.02 log units) below the measured number; the measured number falls inside the stated range.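

In this assay, the link between a nitrogen on the carbonyl carbon and a readable number no longer rests on compound 1 alone. Putting (2-hydroxyethyl)amino in place of 1,3,4-oxadiazol-2-yl gives an at least 2.6-fold lower number from compound 3 to compound 4 (0.42 log units; beyond the scatter), and the comparison with the nitrile gives an at least 2.6-fold lower number from compound 2 to compound 4 (0.42 log units; beyond the scatter), so compound 4 joins compound 1 as the second compound with a number rather than a limit, apart from the two that remain at it: the limit of > 25000 nM in this assay, at which 2 of the 4 values shown sit. The amide nitrogen can also carry a substituent without the number reaching that limit, although replacing the amide hydrogen with 2-hydroxyethyl comes at a modest cost, a 3.0-fold higher number from compound 1 to compound 4 (0.48 log units; beyond the scatter).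

The compounds shown do not tell whether the hydroxyl group or the chain itself accounts for that last step, and an ethyl group on the same nitrogen would help to separate the two. As far as these compounds go, how far this nitrogen accepts other substituents also stays open, for example a longer chain such as 3-hydroxypropyl, or a chain ending in an amine or a carboxylic acid.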